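The compounds below may be only part of what the source reports. "The series", "measured", "known", "first", "only" and "open" are said of these compounds alone.

Three compounds share one core and differ only in the chain attached to the amide nitrogen. In a functional assay on the whole organism (Tail, strain ICR) with Mus musculus as the target, in the tail flick test, with a stated time of 150 min, at a dose of 25 umol/kg by the oral route (on this read-out higher numbers stand for a stronger effect at the one dose given and lower numbers for a weaker effect), compound 1 `NC(=O)CC[C@H](NC(=O)CN(c1ncnc2c1ncn2C1CCCCO1)C1CC1)C(=O)OCc1ccccc1` gives 10.7%, compound 2 `O=C(CN(c1ncnc2c1ncn2C1CCCCO1)C1CC1)NCC(=O)OCc1ccccc1` gives 7.26%, and compound 3 `O=C(CN(c1ncnc2c1ncn2C1CCCCO1)C1CC1)N[C@@H](CC(=O)OCc1ccccc1)C(=O)OCc1ccccc1` gives 0.06%, the lowest of the three numbers, although its gap to compound 2 lies within the scatter and only its gap to compound 1 lies beyond it. Compound 4 `C[C@H](NC(=O)CN(c1ncnc2c1ncn2C1CCCCO1)C1CC1)C(=O)OCc1ccccc1` differs from compound 3 by hydrogen in place of benzyloxycarbonyl on a saturated chain carbon, two bonds along the chain from an amide-type nitrogen and a carbonyl carbon. Among the compounds with values here, two measured steps touch the same part of the chain: a number 10.6 percentage points lower from compound 1 to compound 3 (beyond the scatter), and a number 7.2 percentage points lower from compound 2 to compound 3 (within the scatter). Both point the same way, so taking the benzyloxycarbonyl group away is expected to give a small rise in this assay, a number 7.9 percentage points higher from compound 3 to compound 4 (within the scatter), though it may well stay within the scatter. Compound 4 is therefore expected to reach about 8%, within a range from 0% to 20%.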

Compound 4, a percentage reported as activity, at one dose (the size of the read-out at that dose, not a potency): 6.01%
Beside the measured number, compound 4's estimate is 2 percentage points above it; low and high end bracket the measured number.
By their numbers in this assay, from the lowest: compounds 3, 4, 2 and 1 (each within the scatter of the next, the first and the last beyond it).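

Removing the benzyloxycarbonyl group to leave a plain methyl gives a number 6 percentage points higher from compound 3 to compound 4 (within the scatter) in this assay, and the other two comparisons read a number 1.3 percentage points lower from compound 2 to compound 4 (within the scatter) and a number 4.7 percentage points lower from compound 1 to compound 4 (within the scatter). Compound 4 thus lies within the scatter of all three earlier compounds, so its methyl group cannot be told apart from hydrogen, (benzyloxycarbonyl)methyl or the carbamoylmethyl-bearing chain at this position. No measured evidence explains these numbers. Still open, from the compounds shown here alone, is how this chain carbon would respond to an amine or a carboxylic acid on a longer chain, and whether either would lift the number clear of the scatter.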